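The source may report more compounds than this note shows. Statements on the series, on what has been measured and on what is new or still open speak of the compounds shown alone.

The series keeps the core of compound 1 `CCCc1ccc(C(=O)Nc2cccc(NC(=O)COc3ccc4c(=O)ccoc4c3)c2)cc1` and varies only the group on the carbonyl carbon whose other neighbour is the amide-type nitrogen. In an assay on isolated protein for inhibition of Rho-associated protein kinase 1 (Homo sapiens), read by scintillation counting, radiometric assay and 33P incorporation, with a stated time of 40 min, in the presence of a further agent that is not named here (on this read-out higher numbers stand for weaker inhibition and lower numbers for stronger inhibition), compound 1 gives 143 nM. Going by the values given here, compound 2 `O=C(COc1ccc2c(=O)ccoc2c1)Nc1cccc(NC(=O)c2cccc([N+](=O)[O-])c2)c1` gives 528 nM in this assay, the higher of the two numbers measured so far, and the only other number is separated from it by a 3.7-fold higher number from compound 1 to compound 2 (0.57 log units; beyond the scatter). Compound 3 `Cc1cc(C(=O)Nc2cccc(NC(=O)COc3ccc4c(=O)ccoc4c3)c2)no1` is not yet measured; it differs from compound 2 by 5-methyl-1,2-oxazol-3-yl in place of 3-nitrophenyl on a carbonyl carbon. Among the compounds with values here, the single measured step at this position, a 3.7-fold higher number from compound 1 to compound 2 (0.57 log units; beyond the scatter), shows that exchanging the aryl group on this carbonyl carbon moves the number by a modest amount, but no measured pair tells the direction for a five-membered aromatic ring with 2 hetero atoms. The step from compound 2 to compound 3 is therefore expected to be a 1.3-fold higher number from compound 2 to compound 3 (0.12 log units; within the scatter), close to the scatter. Compound 3 is estimated at 700 nM, with a range of 250 nM to 2500 nM.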

Compound 3, half-maximal inhibitory concentration: 68 nM
Compound 3: the middle estimate sits 10-fold (1.01 log units) above what was measured; the measured number lies below the stated range.
By their numbers in this assay, from the lowest: compound 3; then compound 1; then compound 2.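

In this assay, the group on the carbonyl carbon whose other neighbour is the amide-type nitrogen need not be a six-membered aromatic ring of carbon only. The exchange for 5-methyl-1,2-oxazol-3-yl gives a 7.8-fold lower number from compound 2 to compound 3 (0.89 log units; beyond the scatter), and against the 4-propylphenyl group it gives a 2.1-fold lower number from compound 1 to compound 3 (0.32 log units; beyond the scatter). Compound 3 therefore has the lowest number of the three, so this position can move the number downward as well as upward from compound 1. Nothing at hand bears on the reason for this shift.

On these data alone, whether the lower number belongs to the five-membered ring itself or to its methyl group remains open. Also open, as far as these compounds go, is how the number would respond to a longer chain in place of that methyl, or to an amine or a carboxylic acid on the ring.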